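A few compounds are considered here, and "the series" means these few. Any claim that something is new, unique, unknown or untested is made for them only; others in the source may bear on it.

Working notes on the series. a functional assay on the whole organism (blood, strain Wistar albino) for inhibition, with Rattus norvegicus as the target, read by colorimetric assay, with stated times of 15 min and 90 min, at a dose of 20 mg/kg by the oral route (a lower number here means less inhibition, a higher number more inhibition at the dose given (going by the name of the read-out)), is the read-out throughout. Compound 1 `CCCNC(=O)NS(=O)(=O)c1ccc(-n2nc(-c3ccc(Cl)cc3)ccc2=O)cc1` gives 74.3% in this assay. Compound 2 `O=C(NC1CCCCC1)NS(=O)(=O)c1ccc(-n2nc(-c3ccc(Cl)cc3)ccc2=O)cc1` gives 59% in this assay. For the measured compounds named here, the single measured step between them is a number 15.3 percentage points lower from compound 1 to compound 2 (beyond the scatter), the only change seen so far at the amide-type nitrogen. Compound 2 thus stands lowest of the two numbers; its nearest neighbour is compound 1, which lies higher by a margin beyond the scatter.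

Compound 3 `O=C(NCc1ccccc1)NS(=O)(=O)c1ccc(-n2nc(-c3ccc(Cl)cc3)ccc2=O)cc1` is not yet measured. The change from compound 2 to compound 3 is benzyl in place of cyclohexyl on an amide-type nitrogen. Going by the values given here, no measured step covers benzyl in place of cyclohexyl; the step that bears on this position is a number 15.3 percentage points lower from compound 1 to compound 2 (beyond the scatter), which shows that one swap of the group on the amide-type nitrogen moved this assay by a modest amount. That step gives a sense of the size such a swap can produce, but no direction for an aromatic ring entering where a non-aromatic ring leaves. The expected step in this assay is therefore a number 4 percentage points higher from compound 2 to compound 3 (within the scatter), within the scatter. The estimate for compound 3 is 63%, with a range from 48% to 78%.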

Compound 3, a percentage reported as inhibition, in the whole organism at one dose (the size of the read-out at that dose, not a potency): 61.6%
Beside the measured number, compound 3's estimate is 1.4 percentage points above it, within the range that was stated.
By their numbers in this assay, from the lowest: compounds 2 and 3 (each within the scatter of the next); then compound 1.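

In this assay, benzyl in place of cyclohexyl on the amide-type nitrogen gives a number 2.6 percentage points higher from compound 2 to compound 3 (within the scatter), so this position does not separate the aromatic ring from the non-aromatic ring in these two compounds. Measured against the propyl group, the benzyl group gives a number 12.7 percentage points lower from compound 1 to compound 3 (beyond the scatter), and the cyclohexyl group gives a number 15.3 percentage points lower from compound 1 to compound 2 (beyond the scatter), so among the three compounds both ring-bearing groups stand apart from propyl, while they cannot be told apart from each other. No measurement on hand accounts for these differences.

The compounds shown leave open whether the separation from compound 1 goes with the presence of a ring or with the length of the group, since a butyl or hexyl chain, or a smaller methyl group, does not appear among them. Also open, from the compounds shown here alone, is how this position responds to a group carrying an amine or a carboxylic acid, or to a ring holding nitrogen such as piperidine, and how any of these groups reads at doses other than the single one used here.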